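The compounds below may be only part of what the source reports. "The series", "measured", "known", "first", "only" and "open" are said of these compounds alone.

Compound 1 `CCCCc1nc(C(C)C)c(CC(=O)OC)c(=O)n1Cc1ccc(-c2ccccc2-c2noc(=O)[nH]2)cc1` gives 9.4% in an ADME assay on microsomes from liver (Mus musculus) for metabolic stability, with a stated time of 30 min; a higher number here means that more of the compound is left, a lower number that less of the compound is left. Compound 2 `CCCCOC(=O)Cc1c(C(C)C)nc(CCCC)n(Cc2ccc(-c3ccccc3-c3noc(=O)[nH]3)cc2)c1=O` gives 21.6% in this assay, and compound 3 `CCCCCOC(=O)Cc1c(C(C)C)nc(CCCC)n(Cc2ccc(-c3ccccc3-c3noc(=O)[nH]3)cc2)c1=O` gives 19.7% in this assay, the second highest of the three numbers; it stands nearest to compound 2 and furthest from compound 1. Compound 4 `CCCCc1nc(C(C)C)c(CC(=O)OCC(C)C)c(=O)n1Cc1ccc(-c2ccccc2-c2noc(=O)[nH]2)cc1` differs from compound 3 by isopropyl in place of butyl on a saturated chain carbon bound to an oxygen next to a carbonyl group. Among the compounds with values here, the steps that bear on this are a number 12.2 percentage points higher from compound 1 to compound 2 (beyond the scatter) and a number 10.3 percentage points higher from compound 1 to compound 3 (beyond the scatter), both beyond the scatter, whereas a number 1.9 percentage points lower from compound 2 to compound 3 (within the scatter). Within the data shown here, no measured step tests a branched chain at this place. Because a number 12.2 percentage points higher from compound 1 to compound 2 (beyond the scatter) and a number 10.3 percentage points higher from compound 1 to compound 3 (beyond the scatter) both followed the replacement of hydrogen by a chain, compound 4 with isopropyl is expected to show a step of a number 2.7 percentage points lower from compound 3 to compound 4 (within the scatter) within the scatter. Compound 4 is estimated at 17%, between 8% and 28%.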

Compound 4, percent of the compound remaining: 13.7%
The estimate for compound 4 lay 3.3 percentage points above the measured number, within the range that was stated.
By their numbers in this assay, from the lowest: compounds 1, 4, 3 and 2 (each within the scatter of the next, the first and the last beyond it).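

In this assay the branched chain separates from none of the others: a number 6 percentage points lower from compound 3 to compound 4 (within the scatter) and a number 7.9 percentage points lower from compound 2 to compound 4 (within the scatter) and a number 4.3 percentage points higher from compound 1 to compound 4 (within the scatter) all stay within the scatter. Compound 1 thus lies beyond the scatter from the straight-chain compound 2 and compound 3, but not from compound 4, so the separation seen with propyl and butyl is not repeated with isopropyl at this place. No measurement at hand accounts for this.

Still open, from the compounds shown here alone, is whether a cyclohexyl ester, or an amide in place of the ester, would separate from compound 1 in this assay.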